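This account rests on a few compounds, and the source may have more. Where it says the series, first, only, none or still open, it means among the compounds named here.

Measured so far in a physicochemical assay for permeability, using PAMPA, at pH 7.4; a lower number here means that the compound crosses the layer more slowly, a higher number that the compound crosses the layer faster:
compound 1 `CC(C)(C)NC(=O)NCCS(=O)(=O)NC(=O)c1ccc(Nc2nc(NC3(c4ccc(Cl)cc4)CC3)nc(OCC(F)(F)F)n2)cc1`: 49 nm/s
compound 2 `CC(C)OC(=O)NCCS(=O)(=O)NC(=O)c1ccc(Nc2nc(NC3(c4ccc(Cl)cc4)CC3)nc(OCC(F)(F)F)n2)cc1`: 71 nm/s
compound 3 `CC(=O)NCCS(=O)(=O)NC(=O)c1ccc(Nc2nc(NC3(c4ccc(Cl)cc4)CC3)nc(OCC(F)(F)F)n2)cc1`: 7 nm/s

Compound 3 holds the lowest number of the three. Its nearest neighbour is compound 1, separated from it by a 7.0-fold lower number from compound 1 to compound 3 (0.85 log units; beyond the scatter); compound 2 lies further off, separated by a 10-fold lower number from compound 2 to compound 3 (1.01 log units; beyond the scatter). Compound 1 and compound 2 themselves sit within the scatter of one another, with a 1.4-fold higher number from compound 1 to compound 2 (0.16 log units; within the scatter).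

The next compound, compound 4 `O=C(NS(=O)(=O)CCNCc1ccccc1)c1ccc(Nc2nc(NC3(c4ccc(Cl)cc4)CC3)nc(OCC(F)(F)F)n2)cc1`, alters the end of the chain of compound 3: benzyl in place of acetyl on an amine nitrogen. The two steps that end at compound 3 bear on this most directly, since each of them, read in reverse, swaps the methyl on the carbonyl carbon for a group of more heavy atoms, and each moved this assay upward by a clear margin: a 7.0-fold lower number from compound 1 to compound 3 (0.85 log units; beyond the scatter) and a 10-fold lower number from compound 2 to compound 3 (1.01 log units; beyond the scatter). The present change goes further than either, taking the carbonyl away altogether and bringing in an aromatic ring, so those steps are only a loose guide; the direction they point in is upward. The step from compound 3 to compound 4 is therefore expected to be a rise, of about a 2.9-fold higher number from compound 3 to compound 4 (0.46 log units; beyond the scatter). Compound 4 is estimated at 20 nm/s, with a range from 5 nm/s to 80 nm/s.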

Compound 4, apparent permeability: 49 nm/s
Compound 4: the middle estimate sits 2.5-fold (0.39 log units) below what was measured, and the stated range covers the measured number.
By their numbers in this assay, from the lowest: compound 3; then compounds 1, 4 and 2 (each within the scatter of the next).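

On the amine nitrogen of the chain, benzyl in place of acetyl gives a clear rise in this assay (a 7.0-fold higher number from compound 3 to compound 4 (0.85 log units; beyond the scatter)), so a high number in this small set does not depend on a carbonyl attached to that nitrogen. Compound 4 stands within the scatter of both carbonyl-bearing analogues (a 1.4-fold lower number from compound 2 to compound 4 (0.16 log units; within the scatter); no change at the digits printed from compound 1 to compound 4 (within the scatter)), which leaves benzyl, isopropoxycarbonyl and (tert-butyl)carbamoyl level with one another and acetyl alone apart from them among these four compounds. No measurement at hand explains the rise from acetyl to benzyl or the level reading of the other three groups.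

Still open, going by these compounds, is where a plain methyl, or the unsubstituted amine, would fall on this nitrogen, and so whether acetyl is the outlier or the larger groups share a plateau. Also open, on these data alone, is whether the aromatic ring of benzyl matters or a saturated group such as cyclohexylmethyl would read the same, and how a longer chain between the sulfonyl and this nitrogen would behave.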